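Fluoromethylphenyl to Dimethylphenyl Amide on a Shared Core

The compounds below may be only part of what the source reports. "The series", "measured", "known", "first", "only" and "open" are said of these compounds alone.

Two amides on a shared core have been measured in a functional assay on GTL 16 cells for antiproliferative activity against GTL 16 cell line (Homo sapiens), read by CCK-8 assay, with a stated time of 72 h; on this read-out higher numbers stand for weaker inhibition and lower numbers for stronger inhibition. Compound 1 `O=C(Nc1cccc(-c2oc3cc(-c4ccc(F)cc4)ccc3c(=O)c2O)c1)c1ccc(C(F)(F)F)cc1` gives 33000 nM. Compound 2 `Cc1cc(C(=O)Nc2cccc(-c3oc4cc(-c5ccc(F)cc5)ccc4c(=O)c3O)c2)ccc1F` gives 12100 nM. Among the measured compounds shown here, the step of a 2.7-fold lower number from compound 1 to compound 2 (0.44 log units; beyond the scatter) is the only measured step so far, and it places compound 2 at the lowest of the two numbers, with compound 1 as its nearest neighbour.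

Compound 3 `Cc1cc(C)cc(C(=O)Nc2cccc(-c3oc4cc(-c5ccc(F)cc5)ccc4c(=O)c3O)c2)c1` has not yet been measured. It differs from compound 2 by 3,5-dimethylphenyl in place of 4-fluoro-3-methylphenyl on a carbonyl carbon. For the measured compounds named here, the one measured step that bears on a change at this carbonyl carbon is a 2.7-fold lower number from compound 1 to compound 2 (0.44 log units; beyond the scatter), a modest step. That step exchanged a trifluoromethyl-bearing ring for a ring bearing fluorine and methyl; the new exchange swaps the fluorine for a methyl on the same ring. Going by the values given here, no measured pair reports such a swap, so the size of the step cannot be read from the data. Compound 3 is therefore expected to fall close to compound 2, the step of a 1.2-fold lower number from compound 2 to compound 3 (0.08 log units; within the scatter) being estimated as within the scatter. For compound 3 the expected value in this assay is 10000 nM, with a range from 4000 nM to 25000 nM.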

Compound 3, half-maximal inhibitory concentration: 13500 nM
Compound 3: middle estimate off by 1.4-fold (0.13 log units), on the low side; the range from low to high includes it.
By their numbers in this assay, from the lowest: compounds 2 and 3 (each within the scatter of the next); then compound 1.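

In this assay, placing 3,5-dimethylphenyl on the carbonyl carbon in place of 4-fluoro-3-methylphenyl gives a 1.1-fold higher number from compound 2 to compound 3 (0.05 log units; within the scatter) and thus no distinction between the two rings, which the earlier pair could not show. Placing 3,5-dimethylphenyl in place of 4-(trifluoromethyl)phenyl gives a 2.4-fold lower number from compound 1 to compound 3 (0.39 log units; beyond the scatter) and so shows that, among these three compounds, the modest gap to compound 1 also appears with a ring that carries only methyl groups and no fluorine. Nothing at hand accounts for either step, and the data give no reason for them.

All three amides carry a substituted phenyl ring with only methyl, fluorine or trifluoromethyl on it, and all three numbers stay close together, so the compounds shown do not tell whether this position can support a much lower number. Whether an amine, a carboxylic acid or a longer chain on that ring, or a pyridine in place of it, would shift the value is left open, as is the effect of any change elsewhere on the shared core.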